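Second trifluoromethyl on the anilide ring of compound 1

A few compounds are considered here, and "the series" means these few. Any claim that something is new, unique, unknown or untested is made for them only; others in the source may bear on it.

Compound 1 `C[C@@H](NC(=O)Nc1cccc(C(F)(F)F)c1)c1ccccc1` is the reference point of this pair. In an ADME assay on the whole organism with Oryza sativa as the target, tested at 0.1 uM (on this read-out higher numbers stand for a weaker effect at the one concentration tested and lower numbers for a stronger effect), compound 1 gives 82%, the lower of the two numbers recorded so far. Its closest neighbour is compound 2 `CCOC(=O)c1cccc(NC(=O)N[C@H](C)c2ccccc2)c1`, which in this assay gives 99%; the step of a number 17 percentage points higher from compound 1 to compound 2 (beyond the scatter), ethoxycarbonyl in place of trifluoromethyl on an aromatic carbon, lies beyond the scatter.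

Compound 3 `C[C@@H](NC(=O)Nc1cc(C(F)(F)F)cc(C(F)(F)F)c1)c1ccccc1` has not yet been run in this assay. It differs from compound 1 by trifluoromethyl in place of hydrogen on an aromatic carbon. Going by the values given here, no measured step exchanges hydrogen for trifluoromethyl; the only step recorded, a number 17 percentage points higher from compound 1 to compound 2 (beyond the scatter), swaps one group for another and does not bear directly on the present change. With nothing that speaks for a shift in either direction, the step of a number 4 percentage points lower from compound 1 to compound 3 (within the scatter) is expected to stay within the usual scatter, leaning, if anywhere, slightly lower. Compound 3 is therefore estimated to give 78% in this assay, with a range from 60% to 95%.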

Compound 3, a percentage reported as activity, at one concentration (the size of the read-out at that concentration, not a potency): 100%
For compound 3 the middle estimate is 22 percentage points below the measured one; the measured number lies above the stated range.
By their numbers in this assay, from the lowest: compound 1; then compounds 2 and 3 (each within the scatter of the next).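

In this assay, the addition of a second trifluoromethyl on an aromatic carbon, meta to a trifluoromethyl group, gives a number 18 percentage points higher from compound 1 to compound 3 (beyond the scatter), so this hydrogen-bearing position of the shared core is not indifferent on this read-out, and the number moves toward a weaker effect at the one concentration tested. Going by these compounds alone, until this result the only recorded change was the replacement of the existing trifluoromethyl, a number 17 percentage points higher from compound 1 to compound 2 (beyond the scatter); the new step shows that a change leaving that group in place also raises the number beyond the scatter, and compound 1 still holds the lowest number of the three. Nothing on hand gives a measured reason for this shift.

From the compounds shown here alone, whether the rise belongs to trifluoromethyl itself or would also follow from a chlorine, a methyl or an amine on the same aromatic carbon remains open. Also open, going by these compounds, is whether a single group other than trifluoromethyl, such as a nitrile or a carboxylic acid, could bring the number below that of compound 1 when placed on the anilide ring.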